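Phenoxy step from compound 3 to compound 4

The source may hold more compounds than are shown below. What is called first, only, known or untested is meant among the compounds shown, and "the series" means these compounds.

Measured so far in an ADME assay on MRC5 cells (Homo sapiens) for cytotoxicity, read by fluorescence, with a stated time of 72 h; a lower number here means a stronger inhibitor, a higher number a weaker inhibitor (each value is a limit):
- compound 1 `C[C@]1(COc2ccc(OC(F)(F)F)cc2)Cn2cc([N+](=O)[O-])nc2O1` gives > 64000 nM
- compound 2 `C[C@@]1(COc2ccc(OC(F)(F)F)cc2)Cn2cc([N+](=O)[O-])nc2O1` gives > 64000 nM
- compound 3 `CC1(COc2ccccc2)Cn2cc([N+](=O)[O-])nc2O1` gives > 64000 nM

Compound 3 gives > 64000 nM and this is a limit, not a number. The other two compounds share that position, as shown by the limit of > 64000 nM in this assay, at which 3 of the 3 values shown sit, and no order among the three can be read.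

The change to compound 4 `CC1(COc2ccc(Oc3ccccc3)cc2)Cn2cc([N+](=O)[O-])nc2O1` is phenoxy in place of hydrogen on an aromatic carbon and it puts phenoxy in place of hydrogen on an aromatic carbon, para to a large group.

Among the compounds with values here, the only measured step, a step that the two limits leave unreadable from compound 1 to compound 2 with the fact that compounds 1 and 2 differ only in the configuration as drawn as its full description, concerns configuration alone. It has no readable size and offers no measure for adding phenoxy.

The expectation for compound 4 therefore rests on compound 3 at > 64000 nM and on no numeric value besides. A further limit is the likeliest report for compound 4, while a number somewhat lower remains possible. The estimated step is an at least 1.0-fold lower number from compound 3 to compound 4 (0.02 log units; that floor lies within the scatter) and no large move in this assay is expected. For compound 4 the estimated value is 60000 nM with an expected range from 25000 nM to 64000 nM on this reading.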

Compound 4, half-maximal inhibitory concentration: > 64000 nM
Compound 4: no number, only a limit; the forecaster's own chance of this, stated with the estimate: 70%; middle value at least 1.0-fold (0.02 log units) from the limit.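

In this assay compound 4 gives > 64000 nM, and this is a limit, not a number. No size can be read for the step from compound 3 to compound 4: the limit of > 64000 nM in this assay, at which 4 of the 4 values shown sit.

The compounds shown leave open what value compounds 3 and 4 would give as numbers, and so what phenoxy in place of hydrogen changes.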